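The source may report more compounds than this note shows. Statements on the series, on what has been measured and on what is new or still open speak of the compounds shown alone.

Measured in a functional assay on the whole organism (brain) with Mus musculus as the target; a lower number here means that less compound is needed, a higher number that more compound is needed for the effect:

- compound 1 `COC(=O)c1ccc(OCCc2c[nH]cn2)cc1`: > 3 mg/kg
- compound 2 `CCC(=O)c1ccc(OCCc2c[nH]cn2)cc1`: 0.95 mg/kg
- compound 3 `Clc1ccc(OCCc2c[nH]cn2)cc1`: 0.78 mg/kg

The value of compound 1 is a limit of the assay, not a number. Compound 3 stands level with compound 2, as a 1.2-fold lower number from compound 2 to compound 3 (0.09 log units; within the scatter) shows. Its gap to the limit is wider: an at least 3.8-fold lower number from compound 1 to compound 3 (0.58 log units; beyond the scatter).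

Compound 4 `Brc1ccc(OCCc2c[nH]cn2)cc1` has bromo in place of chloro on an aromatic carbon. Going by the values given here, no measured step makes this exact swap. The nearest evidence is at the same place, where replacing propanoyl with chloro gave a 1.2-fold lower number from compound 2 to compound 3 (0.09 log units; within the scatter), so no change beyond the scatter is expected. The expected step is a 1.0-fold lower number from compound 3 to compound 4 (0.02 log units; within the scatter). Compound 4 is expected to give 0.75 mg/kg, with an estimated range of 0.4 mg/kg to 1.5 mg/kg.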

Compound 4, dose for half-maximal effect: 2.9 mg/kg
Estimate against measurement, compound 4: 3.9-fold (0.59 log units) below; measured number above the stated range.
By their numbers in this assay, from the lowest: compounds 3 and 2 (each within the scatter of the next); then compound 4. At a limit, above all of these: compound 1.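

Bromo in place of chloro on an aromatic carbon gives a 3.7-fold higher number from compound 3 to compound 4 (0.57 log units; beyond the scatter). Compound 4 also separates from the propanoyl compound, with a 3.1-fold higher number from compound 2 to compound 4 (0.48 log units; beyond the scatter), although compound 2 and compound 3 stood level, so this place responds to some changes and not to others. The value of compound 1 is a limit, not a number, so the remaining step, an at least 1.0-fold lower number from compound 1 to compound 4 (0.01 log units; that floor lies within the scatter), cannot be read: the limit of > 3 mg/kg in this assay, at which 1 of the 4 values shown sits.

On these data alone, it remains open whether fluoro or methyl at this place would sit nearer compound 3 or compound 4. The same holds for an amine or a carboxylic acid.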